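Acid in place of anilide on the vinyl dihydrofuran series

The source may report more compounds than this note shows. Statements on the series, on what has been measured and on what is new or still open speak of the compounds shown alone.

Compound 2 `C=CC1=C(C(=O)Nc2ccccc2)C(c2ccc(Cl)c(Cl)c2)OC1` carries the anilide. In a functional assay on HeLa cells (Homo sapiens) for cytotoxicity, read by MTT assay, with a stated time of 24 h (a higher number here means a weaker inhibitor, a lower number a stronger inhibitor), compound 2 gives > 100000 nM, a limit of the assay and not a number. Compound 1 `C=CC1=C(C(=O)NCCC)C(c2ccc(Cl)c(Cl)c2)OC1` gives > 100000 nM, also a limit. Compound 3 `C=CC1=C(C(=O)Nc2ccccc2)C(c2ccc(OC)cc2)OC1` gives > 100000 nM, again a limit. All three values sit at the limit of > 100000 nM in this assay, at which 3 of the 3 values shown sit, so the step that the two limits leave unreadable from compound 1 to compound 2 and the step that the two limits leave unreadable from compound 2 to compound 3 have no readable size. Compound 4 `C=CC1=C(C(=O)O)C(c2ccc(Cl)c(Cl)c2)OC1` differs from compound 2 by hydroxy in place of anilino on a carbonyl carbon. Among the measured compounds shown here, no measured step bears readably on this change, and nothing shows potency emerging. Compound 4 is therefore expected to stand at about 200000 nM, in the range 60000 nM to 600000 nM, and is most likely reported only as a limit. The expected step from compound 2 to compound 4 is thus a step that the limit leaves unreadable from compound 2 to compound 4, that is none beyond the scatter.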

Compound 4, half-maximal inhibitory concentration: 10300 nM
Compound 4: middle estimate off by 19-fold (1.29 log units), on the high side; measured number outside the range, below it.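

Among the compounds shown here, on the carbonyl carbon, hydroxy is the first group here to give a measured number rather than a limit in this assay. Hydroxy in place of anilino gives an at least 9.7-fold lower number from compound 2 to compound 4 (0.98 log units; beyond the scatter), and hydroxy in place of propylamino gives an at least 9.7-fold lower number from compound 1 to compound 4 (0.98 log units; beyond the scatter). Both sizes are only bounds because compound 1 and compound 2 stand at a limit: the limit of > 100000 nM in this assay, at which 3 of the 4 values shown sit. The earlier steps shown here cannot be read.

Open, on these data alone, is whether a methyl ester or a primary amide on this carbonyl carbon would also leave the limit. Also open, as far as these compounds go, is how far the number for compound 4 depends on the 3,4-dichlorophenyl group.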